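Removing the methoxy group from compound 2

The source may hold more compounds than are shown below. What is called first, only, known or untested is meant among the compounds shown, and "the series" means these compounds.

Of the compounds shown here, three sharing one core have been measured in an assay for displacement of a labelled ligand from 5-hydroxytryptamine receptor 4 (Homo sapiens), with a stated time of 60 min, tested at 1 uM; a higher number here means more inhibition at the concentration tested (going by the name of the read-out), a lower number less inhibition. Compound 1 `COc1c(C(=O)CCC2CCN(Cc3ccccc3)CC2)cc(Cl)c2[nH]c([Si](C)(C)C)cc12` gives 62%, compound 3 `COc1c(C(=O)CCC2CCN(Cc3ccccc3)CC2)cc(Cl)c2[nH]ccc12` gives 96%, and compound 2 `COc1c(C(=O)CCC2CCN(CC3CCCCC3)CC2)cc(Cl)c2[nH]ccc12` gives 100%. Compound 2 holds the highest of the three numbers, but compound 3 sits within the scatter of it, a number 4 percentage points lower from compound 2 to compound 3 (within the scatter), so the two cannot be told apart; only compound 1 stands clearly apart, with a number 34 percentage points higher from compound 1 to compound 3 (beyond the scatter).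

Compound 4 `O=C(CCC1CCN(CC2CCCCC2)CC1)c1cc(Cl)c2[nH]ccc2c1` has not yet been measured. It differs from compound 2 in one place: hydrogen in place of methoxy on an aromatic carbon. Neither measured step bears directly on this change. From the compounds shown here alone, the step from compound 1 to compound 3 concerns a group on an aromatic carbon of the other ring, and the step from compound 2 to compound 3 concerns the group on the amine nitrogen; the methoxy group is kept in all three measured compounds, so its contribution is unknown. Because compound 2 gives 100%, there is little room for a higher number, and a loss is the more likely outcome; the size cannot be drawn from the data. Compound 4 is expected to reach 70%, with a range from 35% to 95%, an estimated step of a number 30 percentage points lower from compound 2 to compound 4 (beyond the scatter).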

Compound 4, a percentage reported as inhibition, at one concentration (the size of the read-out at that concentration, not a potency): 100%
Compound 4: the middle estimate sits 30 percentage points below what was measured; measured number above the stated range.
By their numbers in this assay, from the lowest: compound 1; then compounds 3, 2 and 4 (each within the scatter of the next).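

Hydrogen in place of methoxy on this aromatic carbon, para to a chloro group, gives no change at the digits printed from compound 2 to compound 4 (within the scatter) in this assay, the first direct reading on a group that all the earlier compounds carried. With the cyclohexyl group kept on the amine side, the methoxy group is therefore not needed to keep this read-out where it stands at the concentration tested. However, compound 4 gives 100%, the same printed number as compound 2, and as the read-out is a size at one concentration, any difference between the two in the effect at other concentrations would not show this close to the top of the scale; nothing measured here offers an explanation for the result.

From the compounds shown here alone, it remains open whether hydrogen in place of methoxy would leave the number level in compound 3, or in compound 1, whose lower number leaves more room for a change to show. Also open, going by these compounds, is what a hydroxy group, an ethoxy group or an amine would do on this same aromatic carbon, and whether compound 2 and compound 4 would separate at a lower concentration.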